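Propargyl on the amine nitrogen of compound 2

A few compounds are considered here, and "the series" means these few. Any claim that something is new, unique, unknown or untested is made for them only; others in the source may bear on it.

Measured so far:
compound 1, `C[C@H](NCc1ccc(OCc2cccc(F)c2)cc1Cl)C(N)=O`: 12000 nM
compound 2, `C[C@H](NCc1ccc(OCc2cccc(F)c2)cc1F)C(N)=O`: > 10000 nM

In an assay on Sf9 cells for inhibition of Amine oxidase [flavin-containing] A (Homo sapiens), with stated times of 15 min and 60 min (a higher number here means a weaker inhibitor, a lower number a stronger inhibitor), compound 1 gives 12000 nM. For compound 2 this assay reports only a limit, > 10000 nM, so compound 2 stands at the limit of the range and has no numerical value of its own. The step that the limit leaves unreadable from compound 1 to compound 2 cannot be read because of the limit of > 10000 nM in this assay, at which 1 of the 2 values shown sits.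

Compound 3, `C#CCN(Cc1ccc(OCc2cccc(F)c2)cc1F)[C@@H](C)C(N)=O`, differs from compound 2 in one place: propargyl in place of hydrogen on an amine nitrogen. Among the measured compounds shown here, no measured step touches this position; the only measured step concerns the halogen on the aromatic carbon, and its size is not readable. Whether adding propargyl changes inhibition beyond the scatter therefore cannot be judged from these two compounds, and no direction is supported by measured data.

Compound 3 is nevertheless expected to sit at about 2000 nM, with a range from 200 nM to 20000 nM. This estimate means an expected step of an at least 5.0-fold lower number from compound 2 to compound 3 (0.69 log units; beyond the scatter), given as an expectation only, with a real chance that this assay again reports a limit.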

Compound 3, half-maximal inhibitory concentration: 8710 nM
For compound 3 the middle estimate is 4.4-fold (0.64 log units) below the measured one, within the range that was stated.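

In this assay compound 3 gives 8710 nM, so with propargyl on the amine nitrogen the fluoro compound now has a number of its own, which is what this position lacked with hydrogen. Compound 2 gives > 10000 nM, and this is a limit of the assay, not a number. The replacement of hydrogen by propargyl on this nitrogen is recorded as an at least 1.1-fold lower number from compound 2 to compound 3 (0.05 log units; that floor lies within the scatter), so only a floor is known, and the real size of the change may or may not lie beyond the scatter: the limit of > 10000 nM in this assay, at which 1 of the 3 values shown sits.

The step between the chloro and fluoro compounds cannot be read, which leaves open whether propargyl on the amine nitrogen of the chloro compound would give a comparable change. Also open, going by these compounds, is how allyl, with a double bond in place of the triple bond, or methyl or a longer saturated chain on the same nitrogen would compare with propargyl in this assay.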